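The compounds below may be only part of what the source reports. "The series", "measured", "known", "first", "only" and "open" are said of these compounds alone.

Working notes on the series. In an ADME assay on the whole organism (Macaca fascicularis) for pharmacokinetics, read by LC-MS, using cassette dosing, at a dose of 1 mg/kg by the oral route (on this read-out lower numbers stand for lower exposure and higher numbers for higher exposure at the dose given), compound 1 `CCCCN(c1nc2ccccc2o1)[C@H](C)c1ccc(-c2ccccc2-c2nnn[nH]2)cc1` gives 29.2 nM and compound 2 `CCCCN(c1nc2c(CO)cccc2o1)[C@H](C)c1ccc(-c2ccccc2-c2nnn[nH]2)cc1` gives 20.7 nM, with a 1.4-fold lower number from compound 1 to compound 2 (0.15 log units; within the scatter). On this assay compound 2 holds the lower of the two numbers, with compound 1 within the scatter of it. Compound 3 `CCCCN(c1nc2c(NC(C)=O)cccc2o1)[C@H](C)c1ccc(-c2ccccc2-c2nnn[nH]2)cc1` carries acetamido in place of hydroxymethyl on an aromatic carbon. For the measured compounds named here, no measured pair shows this exchange; the single step, from compound 1 to compound 2, stayed within the scatter, so no step beyond the scatter is expected here either, with a 1.2-fold lower number from compound 2 to compound 3 (0.06 log units; within the scatter) as the estimate. Compound 3 is expected to give 18 nM, in a range from 6 nM to 50 nM.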

Compound 3, maximal plasma concentration: 26.6 nM
Compound 3: middle estimate off by 1.5-fold (0.17 log units), on the low side, within the range that was stated.
By their numbers in this assay, from the lowest: compounds 2, 3 and 1 (each within the scatter of the next).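

Acetamido, with 4 heavy atoms against the 2 of hydroxymethyl, gives a second substituent at this aromatic carbon, and in this assay the result lies within the scatter on both readings, with a 1.3-fold higher number from compound 2 to compound 3 (0.11 log units; within the scatter) and with a 1.1-fold lower number from compound 1 to compound 3 (0.04 log units; within the scatter). Neither hydroxymethyl nor acetamido in place of hydrogen is thus separated from compound 1 on this read-out. No data at hand bear on what lies behind these numbers.

As far as these compounds go, whether an amine or a carboxylic acid on this carbon would give a step beyond the scatter remains open.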